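The source may hold more compounds than are shown below. What is called first, only, known or untested is meant among the compounds shown, and "the series" means these compounds.

Compound 1 `CCOC(=O)c1c(-c2cccc([N+](=O)[O-])c2)[nH]c2cc(OC)ccc2c1=O` gives 13000 nM
Compound 2 `CCOC(=O)c1c(-c2ccc(C(C)(C)C)cc2)[nH]c2cc(OC)ccc2c1=O` gives 2000 nM

Both numbers come from a physicochemical assay for solubility, in phosphate buffer, at pH 7.4 (on this read-out higher numbers stand for higher solubility and lower numbers for lower solubility), and compound 1 holds the higher of the two, with a gap to compound 2 that lies beyond the usual scatter of repeat measurements. The next compound to consider is compound 3 `CCOC(=O)c1c(-c2cccc(Cl)c2)[nH]c2cc(OC)ccc2c1=O` which keeps the core of compound 1 and changes a single group. Here 3-nitrophenyl becomes 3-chlorophenyl, with chloro in place of nitro on an aromatic carbon and no measured pair yet differs in only one place. Going by the values given here, the sole guide is compound 2 (at 2000 nM) which shows that a different group can go with a lower number. A moderate drop is therefore expected, only somewhat beyond the scatter, and the estimated change is a 2.6-fold lower number from compound 1 to compound 3 (0.41 log units; beyond the scatter) in this assay with considerable uncertainty. For compound 3 the estimated value is 5000 nM (expected range 1500 nM to 14000 nM).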

Compound 3, solubility: 58000 nM
Beside the measured number, compound 3's estimate is 12-fold (1.06 log units) below it; measured number above the stated range.
By their numbers in this assay, from the lowest: compound 2; then compound 1; then compound 3.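

Going by these compounds alone, compound 1 and compound 3 form the first pair here that differs in one place only, so this assay can now be read for a single change: chloro in place of nitro, on an aromatic carbon meta to a large group, gives a 4.5-fold higher number from compound 1 to compound 3 (0.65 log units; beyond the scatter) and lies beyond the scatter. This position is therefore not indifferent to the group it carries, and in this one pair the smaller group, with no hydrogen-bond acceptors, goes with the higher number. Nothing available here accounts for the rise.

Still open, going by these compounds, is how an amine, a carboxylic acid or a fluoro group at this same position would read. One pair also cannot tell whether the same swap would give a similar step on a different core.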